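Methyl in Place of Methoxy on a Shared Core

A few compounds are considered here, and "the series" means these few. Any claim that something is new, unique, unknown or untested is made for them only; others in the source may bear on it.

Compound 1 `O=C(Nc1cccc(-c2ccc(F)cc2)c1)C(Cl)Cl` gives 26200 nM in a functional assay on KB 3-1 cells (Homo sapiens) for cytotoxicity, read by MTT assay, with a stated time of 68 h; on this read-out lower numbers stand for stronger inhibition and higher numbers for weaker inhibition.
Compound 2 `COc1ccc(-c2cccc(NC(=O)C(Cl)Cl)c2)cc1` reaches only the limit of > 50000 nM in this assay.

Compound 2 stands at the limit of > 50000 nM in this assay, at which 1 of the 2 values shown sits, so no number is known for it; the step of an at least 1.9-fold higher number from compound 1 to compound 2 (0.28 log units; that floor lies within the scatter) is therefore only a floor and does not establish a change beyond the scatter. Compound 3 `Cc1ccc(-c2cccc(NC(=O)C(Cl)Cl)c2)cc1` differs from compound 2 by methyl in place of methoxy on an aromatic carbon. Among the compounds with values here, no measured step exchanges methyl for methoxy; the only step at this position is an at least 1.9-fold higher number from compound 1 to compound 2 (0.28 log units; that floor lies within the scatter), which swaps other groups and lies within the scatter at its floor. Compound 3 is therefore expected to show no step beyond the scatter in this assay, in either direction, with the step of an at least 1.1-fold lower number from compound 2 to compound 3 (0.04 log units; that floor lies within the scatter) as the estimate. On this basis compound 3 is estimated at 45000 nM in this assay, within 15000 nM to 150000 nM.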

Compound 3, half-maximal inhibitory concentration: > 50000 nM
Compound 3 was reported as a limit (the forecaster's own chance of this, stated with the estimate: 45%); middle value at least 1.1-fold (0.04 log units) away from the limit.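

In this assay compound 3 gives a limit and not a number, > 50000 nM. The step between compound 2 and compound 3 cannot be read, so the exchange of methoxy for methyl has no size that can be stated here. The exchange of fluoro for methyl gives an at least 1.9-fold higher number from compound 1 to compound 3 (0.28 log units; that floor lies within the scatter), so a second group at this position yields only a floor, and compound 3 joins compound 2 at the same limit: the limit of > 50000 nM in this assay, at which 2 of the 3 values shown sit.

From the compounds shown here alone, what compound 2 and compound 3 would read past the limit stays unknown, and so does whether either truly differs from compound 1. Also open, going by these compounds, is how an amine or a carboxylic acid at this position would read in this assay, where a value inside the range of the assay would allow a real comparison with compound 1.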